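Swapping an Aryl Carbonyl for an Amino Carbonyl

This account rests on a few compounds, and the source may have more. Where it says the series, first, only, none or still open, it means among the compounds named here.

Compound 1 `C=CCN(CC=C)CC(=O)N1N=C(C)CC1c1cc(Br)ccc1O`: 3090 nM
Compound 2 `COc1ccccc1C1CC(C)=NN1C(=O)CN1CCC(OC)CC1`: 27200 nM
Compound 3 `O=C(c1ccccc1Cl)N1N=C(c2cc3ccccc3oc2=O)CC1c1ccccc1`: 6370 nM

All three compounds were tested in a functional assay on PC-3 cells (Homo sapiens) for cytotoxicity, read by MTT assay, with a stated time of 48 h; on this read-out lower numbers stand for stronger inhibition and higher numbers for weaker inhibition. Compound 1 gives 3090 nM, compound 2 gives 27200 nM and compound 3 gives 6370 nM. Among these three numbers compound 3 stands second highest: compound 1 sits beyond the scatter on the lower side, and compound 2 sits beyond the scatter on the higher side. Among the compounds with values here, none of the three compounds differs from another in a single place, so no measured step connects them.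

Compound 4 `O=C(CNC1CCCCC1)N1N=C(c2cc3ccccc3oc2=O)CC1c1ccccc1` has not yet been measured. It is derived from compound 3 by one change: (cyclohexylamino)methyl in place of 2-chlorophenyl on a carbonyl carbon. The carbonyl thus no longer carries an aromatic ring but a chain that ends in a ring-bearing amine with one hydrogen-bond donor and one acceptor. The measured compounds give no direct guide to this kind of change, and the two compounds whose carbonyl likewise carries an aminomethyl chain, compound 1 and compound 2, lie on opposite sides of compound 3. The expectation is therefore a step of modest size in either direction, not clearly beyond the scatter, giving a 1.2-fold lower number from compound 3 to compound 4 (0.06 log units; within the scatter). Compound 4 is estimated at 5500 nM, expected between 1500 nM and 20000 nM.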

Compound 4, half-maximal inhibitory concentration: 48500 nM
Estimate against measurement, compound 4: 8.8-fold (0.95 log units) below; the whole stated range lies below it.
By their numbers in this assay, from the lowest: compound 1; then compound 3; then compounds 2 and 4 (each within the scatter of the next).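

In this assay, the change of 2-chlorophenyl to (cyclohexylamino)methyl on the carbonyl carbon gives a 7.6-fold higher number from compound 3 to compound 4 (0.88 log units; beyond the scatter), so the group held by this carbonyl clearly matters on this shared core, and this exchange weakens inhibition. The earlier compounds shown here could not show this, since no measured pair among them differed in a single place. The change alters several things at once: a chlorine and an aromatic ring leave, while a nitrogen, with its hydrogen-bond donor and acceptor, and a non-aromatic ring enter, and nothing measured here explains the weaker result or singles out one of these differences.

Going by these compounds, what stays open is which part of the exchange carries the step: cyclohexyl placed directly on the carbonyl would separate the ring from the aminomethyl link, while (phenylamino)methyl would keep that link and restore an aromatic ring. Plain phenyl in the same place would show what the chlorine contributes on the aromatic side, and a single step says nothing yet about how other amines, such as morpholine or piperidine, would behave on this core.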